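Amide Variation on the Shared Core: Cyclopropyl Replacement

The compounds below may be only part of what the source reports. "The series", "measured", "known", "first", "only" and "open" are said of these compounds alone.

Compound 1 `Cc1cc(N2CCC(N3CCCC3C)C2)ccc1NC(=O)C1CCOCC1`: 6.8 nM
Compound 2 `Cc1cc(N2CCC(N3CCCC3C)C2)ccc1NC(=O)C1CC2CCC1C2`: 19.9 nM

In an assay on CHO cells for displacement of a labelled ligand from histamine receptor H3 (Macaca mulatta) (on this read-out lower numbers stand for stronger inhibition and higher numbers for weaker inhibition), compound 2 stands highest of the two numbers; compound 1 gives the lower one. Compound 3 `Cc1cc(N2CCC(N3CCCC3C)C2)ccc1NC(=O)C1CC1` differs from compound 2 by a group of 3 heavy atoms (3 carbon; one three-membered non-aromatic ring of carbon only) in place of a group of 7 heavy atoms (7 carbon; 2 five-membered non-aromatic rings of carbon only), on a carbonyl carbon. Among the compounds with values here, the single step bearing on this position, a 2.9-fold higher number from compound 1 to compound 2 (0.47 log units; beyond the scatter), shows the group on the carbonyl carbon moving the number beyond the scatter. Within the data shown here, the cyclopropyl itself has no direct precedent here, so a return toward the level of compound 1 is expected rather than a further rise. Expected step: a 2.5-fold lower number from compound 2 to compound 3 (0.40 log units; beyond the scatter). Compound 3 is estimated at 8 nM, within 3 nM to 25 nM.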

Compound 3, inhibition constant: 9.6 nM
For compound 3 the middle estimate is 1.2-fold (0.08 log units) below the measured one; the range from low to high includes it.
By their numbers in this assay, from the lowest: compounds 1 and 3 (each within the scatter of the next); then compound 2.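

In this assay, cyclopropyl in place of the carbon-only group with two five-membered rings lowers the number on the carbonyl carbon (a 2.1-fold lower number from compound 2 to compound 3 (0.32 log units; beyond the scatter)), so a carbon-only group there does not by itself bring the higher number. Cyclopropyl and oxan-4-yl are not separated at this position (a 1.4-fold higher number from compound 1 to compound 3 (0.15 log units; within the scatter)), so among the compounds shown the ring oxygen is not needed for a number at this level. No measured evidence accompanies these steps to account for them.

Still open, as far as these compounds go, is how a phenyl ring or an open chain such as tert-butyl on the carbonyl carbon would compare with cyclopropyl in this assay.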